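Bromine to Hydroxyl on a Selenium-Linked Side Chain

The compounds below may be only part of what the source reports. "The series", "measured", "known", "first", "only" and "open" are said of these compounds alone.

Of the compounds shown here, two have been measured so far. Compound 1 `OCC#CCSc1cnc2ccccc2c1[Se]CC#CCBr` and compound 2 `OCC#CCSc1cnc2ccccc2c1SCC#CCBr` share one core and differ only in the atom that ties one of the two side chains to the aromatic ring. In a functional assay on B16 cells (Mus musculus) for cytotoxicity, read by sulforhodamine B assay, with a stated time of 72 h (a lower number here means a stronger inhibitor, a higher number a weaker inhibitor), compound 1 gives 4.6 ug/mL, and compound 2 gives 4.9 ug/mL. The step of a 1.1-fold higher number from compound 1 to compound 2 (0.03 log units; within the scatter) shows that exchanging selenium for sulfur at that position left the number essentially unchanged. Compound 2 therefore holds the higher of the two numbers, but its gap to compound 1 is within the scatter, so the two cannot be ranked against each other.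

Compound 3 `OCC#CCSc1cnc2ccccc2c1[Se]CC#CCO` differs from compound 2 in one place: a group of 6 heavy atoms (4 carbon, 1 oxygen, 1 selenium; no ring) in place of a group of 6 heavy atoms (4 carbon, 1 sulfur, 1 bromine; no ring), on an aromatic carbon. For the measured compounds named here, only one measured step bears on this change, a 1.1-fold higher number from compound 1 to compound 2 (0.03 log units; within the scatter), which covers the sulfur-to-selenium part and was within the scatter. The bromine-to-hydroxyl part has no measured counterpart among these compounds, so its effect is unknown. The expected step of a 1.2-fold higher number from compound 2 to compound 3 (0.09 log units; within the scatter) is small, with wide uncertainty. Compound 3 is estimated at 6 ug/mL, with a range from 2.5 ug/mL to 15 ug/mL.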

Compound 3, concentration for 50% inhibition: 4.3 ug/mL
Compound 3: middle estimate off by 1.4-fold (0.14 log units), on the high side; measured number inside the range.
By their numbers in this assay, from the lowest: compounds 3, 1 and 2 (each within the scatter of the next).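

For the compounds shown here, compound 3 gives the first reading of the bromine-to-hydroxyl exchange with the selenium link held in place: a 1.1-fold lower number from compound 1 to compound 3 (0.03 log units; within the scatter) in this assay, for hydroxy in place of bromo on a saturated chain carbon bound to a triple-bonded carbon. The two numbers cannot be told apart, so the bromine at the chain end is not needed for a number of this size in this pair. The wider exchange, which replaces the sulfur and the bromine together, gives a 1.1-fold lower number from compound 2 to compound 3 (0.06 log units; within the scatter) and also stays within the scatter, so neither exchange at this position separates the compounds in this assay. Nothing shown here gives any measurement that could explain how close these numbers lie.

On these data alone, it remains open whether hydroxy in place of bromo would read the same on a sulfur-linked side chain, as this exchange is seen here only with selenium as the link. As far as these compounds go, it is also open whether an amine, a carboxylic acid or a longer chain at the same chain end would move the number beyond the scatter from compound 3.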